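The source may report more compounds than this note shows. Statements on the series, on what has been measured and on what is new or still open speak of the compounds shown alone.

Compound 1 `COc1ccc(Nc2nc(-c3cccc(F)c3)nc3ccc(F)cc23)cc1` was tested in a functional assay on HL-60 cells (Homo sapiens) for cytotoxicity, read by MTT assay, with a stated time of 48 h (on this read-out higher numbers stand for weaker inhibition and lower numbers for stronger inhibition), where compound 1 gives 38600 nM. Compound 2 `Fc1ccc(Nc2nc(-c3cccc(F)c3)nc3ccc(F)cc23)cc1` carries fluoro in place of methoxy on an aromatic carbon; in this assay compound 2 reaches only the limit of the assay, > 50000 nM. Compound 3 `Fc1cccc(-c2nc(Nc3ccccc3F)c3cc(F)ccc3n2)c1` carries 2-fluorophenyl in place of 4-methoxyphenyl on a nitrogen on an aromatic ring. In this assay compound 3 likewise sits at a limit rather than a number, > 50000 nM. The step of an at least 1.2-fold higher number from compound 1 to compound 3 (0.11 log units; that floor lies within the scatter) is therefore only a floor, and the step that the two limits leave unreadable from compound 2 to compound 3 cannot be read, since both of its values are limits (the limit of > 50000 nM in this assay, at which 2 of the 3 values shown sit). Compound 3 thus stands at the weak end of what this small set shows, as far as a limit allows.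

Compound 4 `Fc1cccc(-c2nc(Nc3ccccc3Cl)c3cc(F)ccc3n2)c1` differs from compound 3 by a single change: chloro in place of fluoro on an aromatic carbon. For the measured compounds named here, no measured step here exchanges chloro for fluoro; the only evidence that bears on it is that compound 3 itself gives no number in this assay, and exchanging one halogen for another on that ring gives no ground to expect a large move. For compound 4 the expected step is a number no higher from compound 3 to compound 4 (the limit leaves the size open), in effect none beyond the scatter. Compound 4 is therefore estimated at 50000 nM, with a range from 15000 nM to 150000 nM, and most likely only a limit would again be reported.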

Compound 4, half-maximal inhibitory concentration: > 50000 nM
Compound 4: a limit, no number (the forecaster's own chance of this, stated with the estimate: 70%); the middle value sits exactly at the limit.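

For the compounds shown here, compound 4 is the first case here of one halogen exchanged for another at this place, 2-chlorophenyl for 2-fluorophenyl, and in this assay the chloro compound also gives a limit, not a number, so neither halogen brings the value into the readable range. Going by these compounds alone, the steps to compound 4 from compound 3 and from compound 2 cannot be read, since both values in each pair are limits, and the series now gathers at a single point: the limit of > 50000 nM in this assay, at which 3 of the 4 values shown sit. The one step that can be read is an at least 1.2-fold higher number from compound 1 to compound 4 (0.11 log units; that floor lies within the scatter), so even the comparison with the only compound that gives a number shows nothing beyond the scatter.

Going by these compounds, how far compound 2, compound 3 and compound 4 lie beyond the limit stays unknown, so the fluoro and chloro compounds cannot be ranked against each other. Also open, on these data alone, is whether a different group on that phenyl ring, such as an amine or a carboxylic acid, would give a number in this assay.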